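A few compounds are considered here, and "the series" means these few. Any claim that something is new, unique, unknown or untested is made for them only; others in the source may bear on it.

Measured so far:
Compound 1 `FC(F)(F)c1ccc(Nc2nc(/C=C/c3ccccc3)nc3ccsc23)cc1`: > 1000000 nM, a limit
Compound 2 `COc1cc(/C=C/c2nc(N3CCN(C)CC3)c3sccc3n2)cc(OC)c1OC`: > 1000000 nM, a limit

Both readings come from a functional assay on L02 cells (Homo sapiens) for inhibition, read by Griess assay, with stated times of 1 h and 24 h; on this read-out higher numbers stand for weaker inhibition and lower numbers for stronger inhibition. Going by the values given here, neither gives a number, so the series offers no measured step to work from. Among the compounds with values here, the position so far is the limit of > 1000000 nM in this assay, at which 2 of the 2 values shown sit. Compound 2 therefore stands only at its limit of > 1000000 nM.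

The next compound is compound 3 `COc1cc(/C=C/c2nc(Nc3ccc(C(F)(F)F)cc3)c3sccc3n2)cc(OC)c1OC`. It has (4-(trifluoromethyl)phenyl)amino in place of 4-methylpiperazin-1-yl on an aromatic carbon of the shared core, next to the ring nitrogen: (4-(trifluoromethyl)phenyl)amino in place of 4-methylpiperazin-1-yl on an aromatic carbon.

Within the data shown here, with no step between measured compounds to size the change, no shift beyond the scatter in this assay is expected, and a direction cannot be argued. The expectation rests on compound 2 with > 1000000 nM, and another limit is the most likely outcome. The expected a number no higher from compound 2 to compound 3 (the limit leaves the size open) stays within the usual scatter. For compound 3 the estimated value is 1000000 nM, with an expected range of 200000 nM to 2000000 nM.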

Compound 3, half-maximal inhibitory concentration: 436000 nM
For compound 3 the middle estimate is 2.3-fold (0.36 log units) above the measured one; the measured number falls inside the stated range.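

In this assay, going by these compounds alone, placing (4-(trifluoromethyl)phenyl)amino in place of 4-methylpiperazin-1-yl gives the first readable number, with an at least 2.2-fold lower number from compound 2 to compound 3 (0.36 log units; beyond the scatter). This shows that the group on this aromatic carbon of the shared core can move the read-out beyond the usual scatter, towards stronger inhibition, although the inhibition of compound 3 remains weak in absolute terms. Without the methoxy groups of compound 3 but with the same (4-(trifluoromethyl)phenyl)amino, compound 1 gives > 1000000 nM, a limit, so that group alone does not guarantee a number in this assay.

Going by these compounds, the true size of the step stays open, because the reading for compound 2 is a limit and such limits still dominate the series: the limit of > 1000000 nM in this assay, at which 2 of the 3 values shown sit. Also open is whether the shift depends on the aromatic ring or on the amine hydrogen, a question that morpholine at this carbon, or a nitrile or carboxylic acid in place of the trifluoromethyl group, could begin to separate.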